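Oxamate analogues: acetamido in place of chloro

The source may report more compounds than this note shows. Statements on the series, on what has been measured and on what is new or still open speak of the compounds shown alone.

Measured compounds:
compound 1, `CCOC(=O)C(=O)Nc1cccc(N2CCCC2)c1C#N`, 83%
compound 2, `CCOC(=O)C(=O)Nc1cccc(Cl)c1C#N`, 56%

In a functional assay on the whole organism for inhibition, with Rattus norvegicus as the target, at a dose of 50 mg/kg by the intraperitoneal route (on this read-out lower numbers stand for less inhibition and higher numbers for more inhibition at the one dose given (going by the name of the read-out)), compound 1 gives 83%, and compound 2 gives 56%. Compound 2 stands lowest of the two numbers shown, with compound 1 its nearest neighbour; the drop a number 27 percentage points lower from compound 1 to compound 2 (beyond the scatter) lies beyond the scatter and is of modest size, brought about by chloro in place of pyrrolidin-1-yl on an aromatic carbon.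

The next compound, compound 3, `CCOC(=O)C(=O)Nc1cccc(NC(C)=O)c1C#N`, has not yet been measured in this assay . Its change from compound 2 is acetamido in place of chloro on an aromatic carbon. For the measured compounds named here, the only measured step that bears on this change is a number 27 percentage points lower from compound 1 to compound 2 (beyond the scatter), where exchanging a nitrogen-linked group for chloro lowered the read-out. Going by the values given here, compound 3 reverses the direction of that exchange, putting a nitrogen-linked group back on the same aromatic carbon, although acetamido is not pyrrolidin-1-yl and no compound bearing acetamido has been measured. A rise in this assay is therefore expected, of a size expected near a number 12 percentage points higher from compound 2 to compound 3 (beyond the scatter). Compound 3 is estimated at 68%, expected between 45% and 88%.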

Compound 3, a percentage reported as inhibition, in the whole organism at one dose (the size of the read-out at that dose, not a potency): 91%
Beside the measured number, compound 3's estimate is 23 percentage points below it; the measured number lies above the stated range.
By their numbers in this assay, from the lowest: compound 2; then compounds 1 and 3 (each within the scatter of the next).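

In this assay, the position ortho to a cyano group proves able to take a second nitrogen-linked group, not just pyrrolidin-1-yl: acetamido in place of chloro gives a number 35 percentage points higher from compound 2 to compound 3 (beyond the scatter), a large step. The earlier pair showed only that chloro fell short of pyrrolidin-1-yl, whereas this result shows that the advantage over chloro does not depend on that ring, since the open-chain acetamido, with its hydrogen-bond donor and acceptor, does as well. Acetamido and pyrrolidin-1-yl cannot be separated at this dose, with a number 8 percentage points higher from compound 1 to compound 3 (within the scatter), so among the three compounds both nitrogen-linked groups stand clear of chloro, and none of the three goes against that, though no information here accounts for it.

The compounds shown leave open whether the gain follows the nitrogen attached to the aromatic carbon or the carbonyl of the acetamido, which a plain amine, a methoxy group or a longer acyl chain such as propionamido at the same carbon could help to separate. They also leave open whether the near parity of compound 1 and compound 3 would persist at other doses, since a single dose gives a size of effect and not a potency.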